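Fluoro in place of methoxy: compound 2 to compound 3

This account rests on a few compounds, and the source may have more. Where it says the series, first, only, none or still open, it means among the compounds named here.

Compound 2 `COc1ccc(Sc2nc3cc(N)cc(N)c3nc2-c2ccccc2)cc1` and compound 1 `CCOC(=O)[C@H](CCC(=O)O)NC(=O)c1ccc(Sc2nc3cc(N)cc(N)c3nc2-c2ccccc2)cc1` share one core. In a functional assay on SF-295 cells (Homo sapiens) for inhibition, read by sulforhodamine B assay, with a stated time of 48 h (on this read-out lower numbers stand for stronger inhibition of growth and higher numbers for weaker inhibition of growth), compound 2 gives only a limit, < 100000 nM. In this assay compound 1 also gives only a limit, < 100000 nM. Both values sit at the limit of < 100000 nM in this assay, at which 2 of the 2 values shown sit, so no measured step can be read between them. Compound 3 `Nc1cc(N)c2nc(-c3ccccc3)c(Sc3ccc(F)cc3)nc2c1` differs from compound 2 by fluoro in place of methoxy on an aromatic carbon. Among the measured compounds shown here, with no measured step to lean on, the expected step that the limit leaves unreadable from compound 2 to compound 3 is none beyond the scatter. Compound 3 is therefore expected to give 30000 nM in this assay, with a range of 5000 nM to 100000 nM.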

Compound 3, concentration for total growth inhibition: 30200 nM
Beside the measured number, compound 3's estimate is 1.0-fold (0.00 log units) below it, within the range that was stated.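

No step can be read between compound 2 and compound 3 in this assay. Compound 2 gives only a limit, < 100000 nM. The compounds shown leave open whether fluoro in place of methoxy changes growth inhibition at all.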